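Swapping Bromine for Fluorine on a Triazole-Linked Aryl Ring

The source may hold more compounds than are shown below. What is called first, only, known or untested is meant among the compounds shown, and "the series" means these compounds.

Within the data shown here, compound 1 `C=C1C(=O)[C@]23C[C@@]1(O)CC[C@H]2c1ccc(O)c(C)c1[C@@H]3Cn1cc(-c2ccccc2)nn1` and compound 2 `C=C1C[C@]23C[C@@]1(O)CC[C@@H]2c1cccc(C)c1[C@@H]3Cn1cc(-c2ccc(Br)cc2)nn1` share a core but differ in several places at once, so no single step between them can be drawn. In a functional assay on SMMC-7721 cells (Homo sapiens) for cytotoxicity, read by MTT assay, with a stated time of 4 days (on this read-out lower numbers stand for stronger inhibition and higher numbers for weaker inhibition), compound 1 gives 1320 nM. Compound 2 returns > 20000 nM in this assay, which is a limit of the assay rather than a number. This is the limit of > 20000 nM in this assay, at which 1 of the 2 values shown sits. Compound 3 `C=C1C[C@]23C[C@@]1(O)CC[C@@H]2c1cccc(C)c1[C@@H]3Cn1cc(-c2ccc(F)cc2)nn1` has not yet been measured; it differs from compound 2 by fluoro in place of bromo on an aromatic carbon. Because compound 2 sits at the limit > 20000 nM, only a change that brings compound 3 back into the measurable range would show as a step, and the measured compounds give no guide to what this swap does. The expectation is therefore no step beyond the scatter, with compound 3 most likely again reported only as a limit. Compound 3 is expected at about 25000 nM, within a range from 8000 nM to 80000 nM, the expected step that the limit leaves unreadable from compound 2 to compound 3 being within the scatter.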

Compound 3, half-maximal inhibitory concentration: > 20000 nM
Compound 3: no number, only a limit; the forecaster's own chance of this, stated with the estimate: 65%; the middle value is on the limit's open side.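

Compound 2 and compound 3 are both reported only as a limit of the assay in this assay, so no step between them can be read: the limit of > 20000 nM in this assay, at which 2 of the 3 values shown sit.

The compounds shown leave open whether fluoro in place of bromo changes the cytotoxicity at all.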